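Swapping a tert-butyl for a basic side chain

A few compounds are considered here, and "the series" means these few. Any claim that something is new, unique, unknown or untested is made for them only; others in the source may bear on it.

Three close relatives share one core and differ only in the group on an amide-type nitrogen in a ring. Compound 1, with the structure `CC(C)(C)N1C(=O)NC2(CSC3=C2C(=O)c2ccccc2C3=O)C1=O`, is the starting point. In a functional assay on MCF7 cells (Homo sapiens) for inhibition (on this read-out higher numbers stand for weaker inhibition and lower numbers for stronger inhibition), compound 1 gives 331 nM, and that single number is all that is known for it, apart from one further entry without a figure. Compound 2, with the structure `CN(C)CCCN1C(=O)NC2(CSC3=C2C(=O)c2ccccc2C3=O)C1=O`, has been measured repeatedly in this assay, giving 19 nM; 19 nM; 27 nM (3 entries). Compound 3, with the structure `CCN(CC)CCCN1C(=O)NC2(CSC3=C2C(=O)c2ccccc2C3=O)C1=O`, is not yet measured. It arises from compound 1 by the change (3-(diethylamino)propyl in place of tert-butyl on an amide-type nitrogen in a ring), that is, 3-(diethylamino)propyl in place of tert-butyl on an amide-type nitrogen in a ring. For the measured compounds named here, no step between two measured compounds is available for this exact change. Still, compound 3 resembles compound 2 far more than compound 1, and because compound 2 shows (the several entries of compound 2 in this assay, 19 nM; 19 nM; 27 nM (3 entries)), a clearly stronger inhibition than compound 1 is expected. The expected step from compound 1 to compound 3 is an 11-fold lower number from compound 1 to compound 3 (1.04 log units; beyond the scatter). Compound 3 is therefore estimated at 30 nM, within a range from 10 nM to 90 nM.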

Compound 3, half-maximal inhibitory concentration: 26 nM
The estimate for compound 3 lay 1.2-fold (0.06 log units) above the measured number; measured number inside the range.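

At this position, on an amide-type nitrogen in a ring, the group makes a large difference in this assay: the change to 3-(diethylamino)propyl gives a 13-fold lower number from compound 1 to compound 3 (1.10 log units; beyond the scatter). For the compounds shown here, this is the first measured step at this position, and it shows that the group entering here can carry a chain with a nitrogen at its end and still reach the low range of numbers seen so far. Compound 3 gives 26 nM, a number that lies among the repeated values of its close relative with two methyl groups instead of two ethyl groups on the chain nitrogen, so the two cannot be told apart here: the several entries of compound 2 in this assay, 19 nM; 19 nM; 27 nM (3 entries)

Going by these compounds, what remains open is whether the step comes from the nitrogen at the end of the chain or from the chain itself, and a plain butyl or pentyl chain with no nitrogen would separate the two. Also open, on these data alone, is how the number responds to a shorter two-carbon or longer four-carbon link to the amine, or to an amine held in a ring, such as piperidine or morpholine.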